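Swapping the Amine Ring of Compound 2

The compounds below may be only part of what the source reports. "The series", "measured", "known", "first", "only" and "open" are said of these compounds alone.

Three compounds have numbers in a functional assay on DLD-1 cells (Homo sapiens) for antiproliferative activity, read by CellTiter-Glo, with a stated time of 72 h; a lower number here means a stronger inhibitor, a higher number a weaker inhibitor. Compound 1 `Cc1noc(C)c1S(=O)(=O)N1CCC(N2CCC(C)CC2)CC1` reaches only the limit of this assay, > 5000 nM. For the measured compounds named here, compound 3 `CC1CCN(C2CCN(S(=O)(=O)c3cnc(Cl)s3)CC2)CC1` gives 1800 nM, and the one change between them, 2-chloro-1,3-thiazol-5-yl in place of 3,5-dimethyl-1,2-oxazol-4-yl on a sulfonyl sulfur, brings an at least 2.7-fold lower number from compound 1 to compound 3 (0.44 log units; beyond the scatter). Compound 2 `Cc1cc(C)c(S(=O)(=O)N2CCC(N3CCC(O)CC3)CC2)c(C)c1` gives 106 nM, the lowest of the two numbers shown, with compound 3 next at a gap beyond the scatter.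

Compound 4 `Cc1cc(C)c(S(=O)(=O)N2CCC(N3CCCCCC3)CC2)c(C)c1` is not yet measured. It differs from compound 2 by azepan-1-yl in place of 4-hydroxypiperidin-1-yl on a saturated ring carbon. No measured step touches this part of the molecule: the single step shown, from compound 1 to compound 3, alters the group on the sulfonyl sulfur, and compound 2 differs from compounds 1 and 3 in more than one place. The step from compound 2 to compound 4 therefore has no anchor, and a small shift, possibly a modest weakening, is expected. Compound 4 is expected to give about 250 nM, between 70 nM and 900 nM. That estimate means a step of a 2.4-fold higher number from compound 2 to compound 4 (0.37 log units; beyond the scatter) for compound 4.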

Compound 4, half-maximal inhibitory concentration: 5.3 nM
The estimate for compound 4 lay 47-fold (1.67 log units) above the measured number; measured number below the stated range.
By their numbers in this assay, from the lowest: compound 4; then compound 2; then compound 3. At a limit, above all of these: compound 1.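

In this assay, swapping the amine ring on the saturated ring carbon brings a 20-fold lower number from compound 2 to compound 4 (1.30 log units; beyond the scatter), so this position has a large effect on the number, which the earlier step, confined to the group on the sulfonyl sulfur, could not show. The two groups have the same number of heavy atoms, so the step does not come with any gain in heavy-atom count. Ring size and the hydroxyl group change together, however: azepan-1-yl is a seven-membered ring without a hydrogen-bond donor, while 4-hydroxypiperidin-1-yl is a six-membered ring with one.

Nothing measured here accounts for the step. Going by these compounds, it remains open whether a plain piperidin-1-yl ring or an azepane ring carrying a hydroxyl group would track the ring size or the hydroxyl group.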